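The compounds below may be only part of what the source reports. "The series", "measured", "known", "first", "only" and "open" are said of these compounds alone.

Measured so far in a functional assay on DU-145 cells (Homo sapiens) for inhibition, read by trypan blue exclusion, with a stated time of 72 h; on this read-out lower numbers stand for stronger inhibition and higher numbers for weaker inhibition:
compound 1 `Cn1c(=O)c(S(=O)(=O)c2ccccc2)cc2cnc(Nc3cnc4[nH]ccc4c3)nc21` gives 1000 nM
compound 2 `Cn1c(=O)c(S(=O)(=O)c2ccccc2)cc2cnc(Nc3ccc4cc[nH]c4c3)nc21` gives 10000 nM

Compound 1 holds the lower of the two numbers. Compound 3 `Cc1ccc(S(=O)(=O)c2cc3cnc(Nc4cnc5[nH]ccc5c4)nc3n(C)c2=O)cc1` keeps the core of compound 1 and turns its phenylsulfonyl into (4-methylphenyl)sulfonyl, a change counted as methyl in place of hydrogen on an aromatic carbon and amounting to methyl in place of hydrogen on an aromatic carbon. Within the data shown here, the only measured step is a 10-fold higher number from compound 1 to compound 2 (1.00 log units; beyond the scatter) and it concerns a different place, the group on a nitrogen on an aromatic ring. Among the measured compounds shown here, no measured compound varies the phenyl ring, so the data offer no size for this change. In this assay no step beyond the scatter is therefore expected. The estimated step is no change at the digits printed from compound 1 to compound 3 (within the scatter) on this reasoning. Compound 3 is expected at 1000 nM with an estimated range from 350 nM to 3000 nM on the same read-out.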

Compound 3, half-maximal inhibitory concentration: 25000 nM
Compound 3: the middle estimate sits 25-fold (1.40 log units) below what was measured, and the stated range ends below it.
By their numbers in this assay, from the lowest: compound 1; then compound 2; then compound 3.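

In this assay, the phenyl ring of the phenylsulfonyl group proves sensitive to one added carbon: methyl in place of hydrogen, on an aromatic carbon para to a large group, gives a 25-fold higher number from compound 1 to compound 3 (1.40 log units; beyond the scatter), and so moves the number towards weaker inhibition. Among these compounds, the earlier compounds varied only the group on a nitrogen on an aromatic ring, so this is the first sign that the phenyl ring also matters in this assay. Nothing measured here bears on why the methyl has this effect.

Among the compounds shown here, the single change leaves open whether any group at this place would do the same or whether the result is particular to methyl; a fluorine atom, a methoxy group or an amine there would separate these cases. From the compounds shown here alone, it also remains open whether unsubstituted phenyl can be replaced at all without a similar rise in the number.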